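Changing the amide cap on a shared core

A few compounds are considered here, and "the series" means these few. Any claim that something is new, unique, unknown or untested is made for them only; others in the source may bear on it.

Compound 2 `Cc1nc(S(C)(=O)=O)ccc1Oc1ncnc(OC2CCN(C(=O)C3(C)CC3)CC2)c1F` is the weaker of the two measured compounds: in a functional assay on isolated protein for inhibition of Glucose-dependent insulinotropic receptor (Homo sapiens), read by HTRF and cAMP accumulation (on this read-out lower numbers stand for an effect already at smaller amounts and higher numbers for an effect only at larger amounts of compound), compound 2 gives 761 nM. Compound 1 `Cc1nc(S(C)(=O)=O)ccc1Oc1ncnc(OC2CCN(C(=O)C(F)(F)F)CC2)c1F`, which carries a trifluoromethyl on the same carbonyl carbon, gives 151 nM in the same assay, and the step of a 5.0-fold higher number from compound 1 to compound 2 (0.70 log units; beyond the scatter) is the only one measured so far. Compound 3 `Cc1nc(S(C)(=O)=O)ccc1Oc1ncnc(OC2CCN(C(=O)c3nc(C(C)(C)F)no3)CC2)c1F` alters the same position again: a group of 9 heavy atoms (5 carbon, 2 nitrogen, 1 oxygen, 1 fluorine; one five-membered aromatic ring with 3 hetero atoms) in place of a group of 4 heavy atoms (4 carbon; one three-membered non-aromatic ring of carbon only), on a carbonyl carbon. Going by the values given here, no measured step involves this new group, so the earlier step only shows that this carbonyl substituent can shift the read-out noticeably. Since compound 1 gave 151 nM with a small, fluorine-bearing group on the carbonyl carbon, a return toward that range is expected, but with wide uncertainty. Compound 3 is therefore estimated at 250 nM, within 60 nM to 1000 nM, which would mean an expected step of a 3.0-fold lower number from compound 2 to compound 3 (0.48 log units; beyond the scatter).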

Compound 3, half-maximal effective concentration: 43.4 nM
The estimate for compound 3 lay 5.8-fold (0.76 log units) above the measured number, outside the stated range (below it).
By their numbers in this assay, from the lowest: compound 3; then compound 1; then compound 2.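

Placing the group with a five-membered aromatic ring on this carbonyl carbon gives an 18-fold lower number from compound 2 to compound 3 (1.24 log units; beyond the scatter), and the same group in place of trifluoromethyl gives a 3.5-fold lower number from compound 1 to compound 3 (0.54 log units; beyond the scatter). The position therefore accepts a group much larger than either earlier one without losing activity, and compound 3 has the lowest number of the three, with both of its steps beyond the scatter. Nothing available here explains why this group gives the lower number.

From the compounds shown here alone, it remains open which part of the new group matters, the aromatic ring or the fluorine-bearing carbon attached to it. Also unresolved is whether a plain phenyl ring or a simple amine on the same carbonyl carbon would give a similar number.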